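Notes on the step from compound 2 to compound 3

The compounds below may be only part of what the source reports. "The series", "measured", "known", "first", "only" and "open" are said of these compounds alone.

Among the measured compounds shown here, compound 2 `COc1cc(OC)c(OC)cc1/C=C/COC(=O)/C=C/c1cccc(Br)c1` gives 25% in a functional assay on the whole organism (strain Kunming) with Mus musculus as the target, with a stated time of 0.5 h, at a dose of 300 mg/kg by the intraperitoneal route (on this read-out higher numbers stand for a weaker effect at the one dose given and lower numbers for a stronger effect), the lower of the two numbers known so far and hence the stronger effect at the single dose. Compound 1 `COc1cc(OC)c(OC)cc1/C=C/COC(=O)/C=C/c1c(OC)ccc(OC)c1OC` gives 50% in this assay, a number higher than that of compound 2 by a margin beyond the scatter. Compound 3 `COc1cc(OC)c(OC)cc1/C=C/COC(=O)/C=C/c1ccccc1Cl` is not yet measured. The change from compound 2 is 2-chlorophenyl in place of 3-bromophenyl on a double-bonded chain carbon bound to a double-bonded chain carbon. For the measured compounds named here, no measured pair covers such a change, so its size cannot be read off; a shift within the scatter is expected, a number 5 percentage points higher from compound 2 to compound 3 (within the scatter). Compound 3 is expected to give about 30%, between 10% and 55%.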

Compound 3, a percentage reported as activity, at one dose (the size of the read-out at that dose, not a potency): 25%
Compound 3: the middle estimate sits 5 percentage points above what was measured, within the range that was stated.
By their numbers in this assay, from the lowest: compounds 2 and 3 (each within the scatter of the next); then compound 1.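

In this assay, 2-chlorophenyl in place of 3-bromophenyl on a double-bonded chain carbon bound to a double-bonded chain carbon gives no change at the digits printed from compound 2 to compound 3 (within the scatter), so this place accepts a change of both the halogen and its place on the ring in a single step without a shift beyond the scatter. Since both change together, neither can be read alone. Nothing at hand explains this result.

Going by these compounds, how an amine or a carboxylic acid on this phenyl ring would read remains open. So does the effect of a longer chain in place of the 2-(2-chlorophenyl)ethenyl group.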